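Moving the fluorine on two related cores

The compounds below may be only part of what the source reports. "The series", "measured", "known", "first", "only" and "open" are said of these compounds alone.

Compound 1 `Oc1ccccc1-c1cc(-c2ccccc2F)cc(-c2ccccc2O)n1` and compound 2 `Oc1ccccc1-c1cc(-c2cccc(F)c2)cc(-c2ccccc2O)n1` share one core, while compound 3 `Oc1ccc(-c2cc(-c3ccccc3F)cc(-c3ccc(O)cc3)n2)cc1` is built on another; how the two cores differ is not broken down here. In a functional assay on HCT-15 cells (Homo sapiens) for inhibition (on this read-out lower numbers stand for stronger inhibition and higher numbers for weaker inhibition), compound 1 gives only a limit, > 50000 nM. Compound 2 likewise gives only a limit in this assay, > 50000 nM. Compound 3 gives 8180 nM in this assay. The change from compound 1 to compound 2 is 3-fluorophenyl in place of 2-fluorophenyl on an aromatic carbon, and the step that the two limits leave unreadable from compound 1 to compound 2; the reason is the limit of > 50000 nM in this assay, at which 2 of the 3 values shown sit. Compound 4 `Oc1ccc(-c2cc(-c3cccc(F)c3)cc(-c3ccc(O)cc3)n2)cc1` carries the same kind of change, (3-fluorophenyl in place of 2-fluorophenyl on an aromatic carbon), the place being meta to two 4-hydroxyphenyl groups rather than meta to two 2-hydroxyphenyl groups. Because the measured pair leaves a step that the two limits leave unreadable from compound 1 to compound 2 unreadable, he expects a step of about a 1.0-fold lower number from compound 3 to compound 4 (0.01 log units; within the scatter). His estimate for compound 4 in this assay is 8000 nM, between 2500 nM and 25000 nM.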

Compound 4, half-maximal inhibitory concentration: > 50000 nM
Compound 4 ended at the assay's limit; the forecaster's own chance of this, stated with the estimate: 15%; at least 6.2-fold (0.79 log units) between middle value and limit.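

In this assay, 3-fluorophenyl in place of 2-fluorophenyl on the core of compound 3 gives an at least 6.1-fold higher number from compound 3 to compound 4 (0.78 log units; beyond the scatter), so inhibition is weaker after the change on this core. Compound 4 gives only a limit, > 50000 nM. This shows a real loss on one core but not its full size, and it does not show that the change acts alike on both cores, because the step from compound 1 to compound 2 cannot be read: the limit of > 50000 nM in this assay, at which 3 of the 4 values shown sit.

The compounds shown leave open whether the fluorine itself matters on the core of compound 3. An amine or a carboxylic acid in its place could keep a readable value or reach the same limit.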